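The source may report more compounds than this note shows. Statements on the series, on what has been measured and on what is new or still open speak of the compounds shown alone.

In a functional assay on MCF7 cells (Homo sapiens) for antiproliferative activity, read by MTT assay, with a stated time of 72 h (on this read-out lower numbers stand for stronger inhibition and higher numbers for weaker inhibition), compound 2 `Nc1nc(N)c2cc(CSC(=S)N3CCN(c4ccc(Cl)c(Cl)c4)CC3)ccc2n1` gives 2370 nM and compound 1 `Cc1ccccc1N1CCN(C(=S)SCc2ccc3nc(N)nc(N)c3c2)CC1` gives 4230 nM, two values within the scatter of each other. That single measured step, a 1.8-fold lower number from compound 1 to compound 2 (0.25 log units; within the scatter), exchanges 2-methylphenyl for 3,4-dichlorophenyl on an amine nitrogen in a ring. Compound 3 `CC(=O)c1ccc(N2CCN(C(=S)SCc3ccc4nc(N)nc(N)c4c3)CC2)cc1` carries a new group at the same place: 4-acetylphenyl in place of 3,4-dichlorophenyl on an amine nitrogen in a ring. Among the measured compounds shown here, with only that step within the scatter to go on, no shift beyond the scatter is expected in this assay, in either direction. Compound 3 is estimated at 3000 nM, with an expected range from 1000 nM to 8500 nM. The expected change is a 1.3-fold higher number from compound 2 to compound 3 (0.10 log units; within the scatter).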

Compound 3, half-maximal inhibitory concentration: 2490 nM
Beside the measured number, compound 3's estimate is 1.2-fold (0.08 log units) above it, and the stated range covers the measured number.
By their numbers in this assay, from the lowest: compounds 2, 3 and 1 (each within the scatter of the next).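

Among the compounds shown here, at this place, on an amine nitrogen in a ring, 4-acetylphenyl is the only group of the three with a hydrogen-bond acceptor, yet in this assay the result is a 1.1-fold higher number from compound 2 to compound 3 (0.02 log units; within the scatter) and a 1.7-fold lower number from compound 1 to compound 3 (0.23 log units; within the scatter). The three phenyl groups shown therefore cannot be told apart on this read-out, even with a carbonyl present. Nothing available bears on why this is so. Still open, from the compounds shown here alone, is whether a benzyl group, a pyridine ring or a plain alkyl chain at this place would give a step beyond the scatter.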